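The compounds below may be only part of what the source reports. "The series", "measured", "known", "first", "only" and "open" are said of these compounds alone.

Compound 1, `Nc1c([S+]([O-])CCCCl)sc2nc(-c3cccs3)cc(-c3ccccc3)c12`: in an assay for inhibition of 15-hydroxyprostaglandin dehydrogenase [NAD(+)] (Homo sapiens), read by fluorescence, with a stated time of 15 min, in the presence of a further agent that is not named here (on this read-out lower numbers stand for stronger inhibition and higher numbers for weaker inhibition), compound 1 gives 4 nM.
Compound 2, `CCOC(=O)c1sc2nc(-c3cccs3)cc(-c3ccccc3)c2c1N`: in this assay compound 2 reaches only a limit of the assay, > 7500 nM.
Compound 3, `CCCCS(=O)(=O)c1sc2nc(-c3cccs3)cc(-c3ccccc3)c2c1N`: in this assay compound 3 gives 25 nM.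

For the measured compounds named here, of the two numbers known in this assay, compound 3 stands highest; its nearest neighbour is compound 1, with a 6.3-fold higher number from compound 1 to compound 3 (0.80 log units; beyond the scatter). Compound 2 sits at a limit, (the limit of > 7500 nM in this assay, at which 1 of the 3 values shown sits), and gives no number.

The unmeasured compound 4, `CCCNC(=O)c1sc2nc(-c3cccs3)cc(-c3ccccc3)c2c1N`, differs from compound 3 in one place: propylcarbamoyl in place of butylsulfonyl on an aromatic carbon. Going by the values given here, two measured steps bear on this exchange at the same aromatic carbon. The first is an at least 300-fold lower number from compound 2 to compound 3 (2.47 log units; beyond the scatter); the second is an at least 1800-fold higher number from compound 1 to compound 2 (3.27 log units; beyond the scatter). Both show that butylsulfonyl and the group carried by compound 1 keep inhibition strong and within a modest step of each other, whereas ethoxycarbonyl at that carbon sends the number past the limit. Propylcarbamoyl resembles ethoxycarbonyl in its carbonyl-bearing build more than it resembles butylsulfonyl, so a large rise in the number is expected, with a real chance that only a limit is reported. Compound 4 is therefore estimated at 1500 nM, with a range from 200 nM to 9000 nM. That estimate means a step of a 60-fold higher number from compound 3 to compound 4 (1.78 log units; beyond the scatter).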

Compound 4, half-maximal inhibitory concentration: > 7500 nM
Compound 4: only a limit was reported; the forecaster's own chance of this, stated with the estimate: 35%; middle value at least 5.0-fold (0.69 log units) away from the limit.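

Set against butylsulfonyl on the aromatic carbon next to the ring sulfur, propylcarbamoyl brings a large loss in this assay (an at least 300-fold higher number from compound 3 to compound 4 (2.47 log units; beyond the scatter)), and the step from the group of compound 1 is larger still (an at least 1800-fold higher number from compound 1 to compound 4 (3.27 log units; beyond the scatter)). The loss at this position is therefore not confined to ethoxycarbonyl, since putting propylamino in place of ethoxy on the carbonyl carbon does not recover a readable number. Among these four compounds, the two carbonyl-bearing groups give only limits and the two sulfur-bearing groups give numbers, with no compound going against that split.

Compound 4 gives only a limit, and it shares that limit with compound 2, so the step between them cannot be read: the limit of > 7500 nM in this assay, at which 2 of the 4 values shown sit.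

On these data alone, how far compound 2 and compound 4 lie beyond that limit stays open, so the ester and the amide cannot be ranked against each other. Also open, as far as these compounds go, is whether a sulfonamide, a methylsulfonyl group or a carboxylic acid on this carbon would fall with the sulfur-bearing groups or with the carbonyl-bearing ones.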